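The compounds below may be only part of what the source reports. "The series", "measured", "known", "first", "only" and "open" are said of these compounds alone.

Values in an ADME assay on BJ cells (Homo sapiens) for cytotoxicity, with a stated time of 72 h; a lower number here means that less compound is needed, a higher number that more compound is needed for the effect:
- Compound 1 (`C=C[C@@](C)(/C=C/c1ccc(O)c(CO)c1)CCC=C(C)C`): > 36600 nM (a limit of the assay)
- Compound 2 (`C=C[C@@](C)(/C=C/c1ccc(O)c(/C=C/C(N)=O)c1)CCC=C(C)C`): > 36600 nM (a limit of the assay)
- Compound 3 (`COc1ccc(/C=C/[C@@](C)(/C=C/c2ccc(O)c(C=O)c2)CCC=C(C)C)cc1`): 9800 nM

Going by the values given here, compound 3 at 9800 nM carries the only actual number in this small set. The other two entries are limits and not numbers, as shown by the limit of > 36600 nM in this assay, at which 2 of the 3 values shown sit (the whole of the comparison available here).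

Compound 4 (`COc1ccc(/C=C/[C@@](C)(/C=C/c2ccc(O)c(/C=C/C(C)=O)c2)CCC=C(C)C)cc1`) is compound 3 with 2-acetylethenyl in place of formyl on an aromatic carbon, ortho to a hydroxy group (2-acetylethenyl in place of formyl on an aromatic carbon). Among the compounds with values here, the one measured step that bears on this change also brings a 2-substituted ethenyl group onto an aromatic carbon, with 2-carbamoylethenyl in place of hydroxymethyl. That step is a step that the two limits leave unreadable from compound 1 to compound 2 (both ends are limits, so it offers neither size nor direction). It also starts from a different group and a different core, so it transfers only loosely. No step beyond the scatter is therefore expected in this assay for this replacement, and no direction is favoured. The expected outcome is a 1.0-fold higher number from compound 3 to compound 4 (0.01 log units; within the scatter) (an estimate with wide margins). A result reported only as a limit remains possible. For compound 4 the estimated value is 10000 nM (expected range 3500 nM to 30000 nM).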

Compound 4, half-maximal effective concentration: 12300 nM
The estimate for compound 4 lay 1.2-fold (0.09 log units) below the measured number; measured number inside the range.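

In this assay, the replacement of formyl by 2-acetylethenyl on an aromatic carbon, ortho to a hydroxy group, gives a 1.3-fold higher number from compound 3 to compound 4 (0.10 log units; within the scatter). Going by these compounds alone, the only earlier step at this position joins two limits and cannot be read, so this pair is the first to give a size for a replacement here. On the core of compound 3, formyl with 2 heavy atoms and 2-acetylethenyl with 5 heavy atoms, each with 1 hydrogen-bond acceptor and 0 hydrogen-bond donors, are not separated beyond the scatter in this assay.

Going by these compounds, compound 1 and compound 2 remain limits and not numbers, and each differs from compound 3 and compound 4 in more than one place, so the pair gives no reading of what the rest of the core contributes: the limit of > 36600 nM in this assay, at which 2 of the 4 values shown sit. Still open is how an amine, a carboxylic acid or a longer chain at this position would read in this assay, and whether hydroxymethyl or 2-carbamoylethenyl on the core of compound 3 would give a number rather than a limit.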